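Vinyl thioether series: replacing the aryl on the alkene carbon

A few compounds are considered here, and "the series" means these few. Any claim that something is new, unique, unknown or untested is made for them only; others in the source may bear on it.

Measured compounds:
- compound 1, `Cc1ccc(S/C(=C/c2ccc(Br)cc2)C(=O)c2ccc(Cl)cc2)cc1`: 25000 nM
- compound 2, `O=C(/C(=C\c1ccc(Br)cc1)Sc1ccc(Br)cc1)c1ccc(Cl)cc1`: 1000 nM
- compound 3, `Cc1ccc(S/C(=C/c2ccc(-c3ccccc3)cc2)C(=O)c2ccc(Cl)cc2)cc1`: 50000 nM

In a functional assay on DU-145 cells (Homo sapiens) for inhibition, read by trypan blue exclusion, with a stated time of 96 h (on this read-out higher numbers stand for weaker inhibition of growth and lower numbers for stronger inhibition of growth), compound 1 stands second highest of the three numbers. Its nearest neighbour is compound 3, where the step of a 2.0-fold higher number from compound 1 to compound 3 (0.30 log units; within the scatter) lies within the scatter. The furthest is compound 2, reached by a 25-fold lower number from compound 1 to compound 2 (1.40 log units; beyond the scatter), a large step that concerns a different place in the shared core.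

Compound 4, `Cc1ccc(S/C(=C/c2sccc2C)C(=O)c2ccc(Cl)cc2)cc1`, differs from compound 1 by 3-methylthiophen-2-yl in place of 4-bromophenyl on a double-bonded chain carbon bound to a double-bonded chain carbon. Going by the values given here, of the two measured steps, only the one from compound 1 to compound 3 touches the same place, and it lies within the scatter. The step from compound 1 to compound 2 alters the other aromatic ring and does not bear on the present change. Among the compounds with values here, there is no measured example of a five-membered ring with a hetero atom at this place, so the expectation rests on the one small step at this place.

For compound 4 in this assay no step beyond the scatter is expected, so the estimate is no change at the digits printed from compound 1 to compound 4 (within the scatter). The estimated value for compound 4 is 25000 nM, with a range from 8000 nM to 80000 nM.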

Compound 4, concentration for 50% growth inhibition: 50000 nM
For compound 4 the middle estimate is 2.0-fold (0.30 log units) below the measured one; the range from low to high includes it.
By their numbers in this assay, from the lowest: compound 2; then compounds 1, 3 and 4 (each within the scatter of the next).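

In this assay, 3-methylthiophen-2-yl in place of 4-bromophenyl gives a 2.0-fold higher number from compound 1 to compound 4 (0.30 log units; within the scatter), so a five-membered aromatic ring with 1 hetero atom is tolerated on this double-bonded chain carbon without a step beyond the scatter. The earlier step at this place, a 2.0-fold higher number from compound 1 to compound 3 (0.30 log units; within the scatter), kept the six-membered ring and changed only its substituent, whereas this one replaces the ring itself; both replacements stay within the scatter, and among the compounds shown the only large step remains the one at the other aromatic ring, a 25-fold lower number from compound 1 to compound 2 (1.40 log units; beyond the scatter). No measurement at hand accounts for the result at this place.

The compounds shown all keep an uncharged aromatic ring at this place, so it remains open whether an amine or a carboxylic acid on that ring, or a saturated ring such as piperidine in its stead, would move the number beyond the scatter. On these data alone, it is also open whether 3-methylthiophen-2-yl would hold its standing on the background of compound 2, which gives 1000 nM, since the two changes are not seen together in any compound here.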